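The source may report more compounds than this note shows. Statements on the series, on what has been measured and on what is new or still open speak of the compounds shown alone.

In an ADME assay on HEK293 cells (Homo sapiens) for cytotoxicity, read by CellTiter-Glo, with a stated time of 72 h (a higher number here means a weaker inhibitor, a lower number a stronger inhibitor), compound 1 (`O=C(NC1CCCCC1)c1c[nH]c2ccc(S(=O)(=O)Nc3ccc(C(F)(F)F)cc3)cc2c1=O`) gives > 50000 nM, a limit and not a number. Compound 2 (`Cc1ccccc1-c1ccc2[nH]cc(C(=O)NCc3cccc(C(F)(F)F)c3)c(=O)c2c1`) gives > 50000 nM, likewise only a limit. Compound 2 therefore stands at the limit of > 50000 nM in this assay, at which 2 of the 2 values shown sit, with no number to rank it. Compound 3 (`Cc1ccccc1-c1ccc2[nH]cc(C(=O)NCc3cccc(Br)c3)c(=O)c2c1`) has bromo in place of trifluoromethyl on an aromatic carbon, meta to a large group: bromo in place of trifluoromethyl on an aromatic carbon. For the measured compounds named here, no measured step in this assay is available as a guide, so the estimated step of a number no higher from compound 2 to compound 3 (the limit leaves the size open) is expected to stay within the scatter, in neither direction. Compound 3 is expected at 50000 nM, with an estimated range from 20000 nM to 100000 nM.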

Compound 3, half-maximal inhibitory concentration: > 50000 nM
Compound 3 was reported as a limit; the forecaster's own chance of this, stated with the estimate: 80%; the middle value lies on the limit itself.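

Compound 2 and compound 3 are both reported only as limits in this assay, so no step between them can be read: the limit of > 50000 nM in this assay, at which 3 of the 3 values shown sit.

The compounds shown leave open whether bromo in place of trifluoromethyl changes the half-maximal inhibitory concentration at all.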